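A few compounds are considered here, and "the series" means these few. Any claim that something is new, unique, unknown or untested is made for them only; others in the source may bear on it.

Measured compounds:
compound 1, `CCC/N=C(\NC#N)Nc1cccnc1` — in a functional assay on the whole organism (blood, strain Wistar-Okamoto) with Rattus norvegicus as the target, with a stated time of 5 days (on this read-out higher numbers stand for an effect only at larger amounts of compound and lower numbers for an effect already at smaller amounts), compound 1 gives 20 mg/kg
compound 2, `CC(C)CC/N=C(\NC#N)Nc1cccnc1` — in this assay compound 2 gives 20 mg/kg

Compound 2 stands level with compound 1 at the digits shown: the one step measured in the series, no change at the digits printed from compound 1 to compound 2 (within the scatter), reads as no change within the scatter when isopropyl replaces methyl on the saturated chain carbon two bonds along the chain from the double-bonded nitrogen. Both compounds share the same core; only that chain differs.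

Compound 3, `CCCCCCC/N=C(\NC#N)Nc1cccnc1`, has not been measured. It differs from compound 2 by pentyl in place of isopropyl on a saturated chain carbon, two bonds along the chain from a double-bonded nitrogen. Among the compounds with values here, the only step that bears on it is the one from compound 1 to compound 2, which enlarged the same chain at the same place and produced no change beyond the scatter. The present change again enlarges that chain, though by a longer and straighter group; nothing in the series shows how far the chain can grow before the read-out moves. Within the data shown here, on the one step available, the expected step of no change at the digits printed from compound 2 to compound 3 (within the scatter) is none beyond the scatter. In this assay compound 3 is therefore expected to give about 20 mg/kg, with a range from 10 mg/kg to 40 mg/kg.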

Compound 3, minimum effective dose: > 50 mg/kg
Compound 3: only a limit was reported (the forecaster's own chance of this, stated with the estimate: 10%); middle value at least 2.5-fold (0.39 log units) away from the limit.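

In this assay, the chain turns out not to be open to unlimited growth: with pentyl in place of isopropyl on a saturated chain carbon, two bonds along the chain from a double-bonded nitrogen, the read-out shows an at least 2.5-fold higher number from compound 2 to compound 3 (0.39 log units; beyond the scatter). Within the data shown here, measured from the shorter chain, with butyl in place of hydrogen on a saturated chain carbon, three bonds along the chain from a double-bonded nitrogen, it shows an at least 2.5-fold higher number from compound 1 to compound 3 (0.39 log units; beyond the scatter), whereas the earlier change at this part of the chain gave no change at the digits printed from compound 1 to compound 2 (within the scatter), so this is the first sign that the read-out responds to the chain at all. The figure for compound 3 is a limit and not a number, so both new steps have a floor but no fixed size: the limit of > 50 mg/kg in this assay, at which 1 of the 3 values shown sits.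

Open, on these data alone, is whether the read-out shifts gradually or abruptly along the series, which a straight hexyl chain on the same nitrogen would help to settle. Also open, as far as these compounds go, is whether length alone carries the shift, or whether a chain of similar reach ending in a hydroxyl group or an amine would read the same.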